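This account rests on a few compounds, and the source may have more. Where it says the series, first, only, none or still open, it means among the compounds named here.

In an in vitro ADME assay on microsomes from liver (Simiiformes) (a lower number here means that the compound disappears faster, a higher number that the compound lasts longer), compound 1 `COCc1cc(CCCOc2c(C)cc(-c3noc(C4CC4)n3)cc2C)on1` gives > 2.5 h, which is a limit of the assay and not a number. Compound 2 `Cc1cc(-c2noc(C3CC3)n2)cc(C)c1OCCCc1cc(CO)no1` gives > 2.5 h, also a limit and not a number. So compound 2 has no exact value, and the data show only that both compounds sit at the limit of > 2.5 h in this assay, at which 2 of the 2 values shown sit. For the measured compounds named here, the one measured step is a step that the two limits leave unreadable from compound 1 to compound 2, so it offers no size to carry forward.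

Compound 3 `CCOc1cc(CCCOc2c(C)cc(-c3noc(C4CC4)n3)cc2C)on1` changes a single place in compound 2: ethoxy in place of hydroxymethyl on an aromatic carbon. In words, this is ethoxy in place of hydroxymethyl on an aromatic carbon. Going by the values given here, no measured step covers this exchange, so no direction can be argued from the data, and no shift beyond the scatter is expected. The expected result in this assay is a number no higher from compound 2 to compound 3 (the limit leaves the size open). For compound 3 the estimated half-life is 2.5 h, with an estimated range of 1.3 h to 5 h.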

Compound 3, half-life: > 2.5 h
Compound 3 ended at the assay's limit (the forecaster's own chance of this, stated with the estimate: 60%); the middle value lies on the limit itself.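

No step among compound 1, compound 2 and compound 3 can be read in this assay, since each result is a limit of the assay and not a number: the limit of > 2.5 h in this assay, at which 3 of the 3 values shown sit.

On these data alone, how long each compound truly lasts, and whether methoxymethyl, hydroxymethyl or ethoxy on this aromatic carbon changes that, stays open.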